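This account rests on a few compounds, and the source may have more. Where it says the series, first, only, none or still open, it means among the compounds named here.

In an ADME assay on L02 cells (Homo sapiens) for cytotoxicity, read by MTT assay, with a stated time of 24 h (a lower number here means a stronger inhibitor, a higher number a weaker inhibitor), compound 1 `O=C1/C(=C/c2ccncc2)CN(S(=O)(=O)c2ccc([N+](=O)[O-])cc2)C/C1=C\c1ccccc1C(F)(F)F` gives 18600 nM and compound 2 `O=C1/C(=C/c2ccncc2)CN(S(=O)(=O)c2ccc(F)cc2)C/C1=C\c1ccccc1C(F)(F)F` gives 12900 nM so compound 2 stands level with compound 1 within the scatter. Compound 3 `O=C1/C(=C/c2ccncc2)CN(S(=O)(=O)c2ccc(Cl)cc2)C/C1=C\c1ccccc1C(F)(F)F` differs from compound 2 by chloro in place of fluoro on an aromatic carbon para to a large group. Among the compounds with values here, the one measured step that bears on this, fluoro in place of nitro on an aromatic carbon, is a 1.4-fold lower number from compound 1 to compound 2 (0.16 log units; within the scatter) and it stays within the scatter. In this assay nothing beyond the scatter is therefore expected (estimated a 1.0-fold higher number from compound 2 to compound 3 (0.00 log units; within the scatter)) and neither direction is favoured. The estimate for compound 3 is 13000 nM (expected range 7000 nM to 24000 nM).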

Compound 3, half-maximal inhibitory concentration: 14900 nM
Compound 3: the middle estimate sits 1.1-fold (0.06 log units) below what was measured, within the range that was stated.
By their numbers in this assay, from the lowest: compounds 2, 3 and 1 (each within the scatter of the next).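

In this assay, chloro in place of fluoro gives a 1.2-fold higher number from compound 2 to compound 3 (0.06 log units; within the scatter), and chloro in place of nitro gives a 1.2-fold lower number from compound 1 to compound 3 (0.10 log units; within the scatter). Nitro, fluoro and chloro on this aromatic carbon therefore all stand level within the scatter, a comparison that now spans three groups rather than two. Nothing measured here offers an explanation for this result.

Going by these compounds, whether an amine, a carboxylic acid or a longer chain at this place would give a step beyond the scatter remains open. So does whether changes elsewhere on the shared core would do so.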